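Propyl for phenyl on the ring amide nitrogen

A few compounds are considered here, and "the series" means these few. Any claim that something is new, unique, unknown or untested is made for them only; others in the source may bear on it.

Compound 1 `O=C(O)c1cc(-c2cccc(COc3ccc4c(c3)CN(c3ccccc3)C4=O)c2)ccc1Cl` carries a phenyl on the amide-type nitrogen of its shared core and in an assay on HEK293 cells for positive allosteric modulation of metabotropic glutamate receptor 2 (Rattus norvegicus), read by thallium flux (on this read-out lower numbers stand for an effect already at smaller amounts and higher numbers for an effect only at larger amounts of compound), compound 1 gives 260 nM, the highest number among the three measured compounds. Compound 2 `CC(C)N1Cc2cc(OCc3cccc(-c4ccc(Cl)c(C(=O)O)c4)c3)ccc2C1=O` gives 70 nM and compound 3 `CC(C)CN1Cc2cc(OCc3cccc(-c4ccc(Cl)c(C(=O)O)c4)c3)ccc2C1=O` gives 100 nM. The steps of a 3.7-fold lower number from compound 1 to compound 2 (0.57 log units; beyond the scatter) and a 2.6-fold lower number from compound 1 to compound 3 (0.41 log units; beyond the scatter) both lie beyond the scatter, while a 1.4-fold higher number from compound 2 to compound 3 (0.15 log units; within the scatter) stays within it, so the two small alkyl groups on that nitrogen read alike.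

Compound 4 `CCCN1Cc2cc(OCc3cccc(-c4ccc(Cl)c(C(=O)O)c4)c3)ccc2C1=O` is not yet measured. It differs from compound 1 by propyl in place of phenyl on an amide-type nitrogen in a ring. The relevant measured steps are the replacements of the same phenyl by isopropyl and by isobutyl, both modest and in the same direction. A propyl group is expected to behave like those alkyls, so a modest step to a lower number in this assay is expected, a 2.9-fold lower number from compound 1 to compound 4 (0.46 log units; beyond the scatter). Compound 4 is therefore estimated at 90 nM in this assay, with a range from 45 nM to 180 nM.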

Compound 4, half-maximal effective concentration: > 10000 nM
Compound 4 gave a limit, no number; the forecaster's own chance of this, stated with the estimate: 2%; middle value at least 110-fold (2.04 log units) from the limit.
By their numbers in this assay, from the lowest: compounds 2 and 3 (each within the scatter of the next); then compound 1. At a limit, above all of these: compound 4.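

In this assay compound 4 gives a limit, not a number: the limit of > 10000 nM in this assay, at which 1 of the 4 values shown sits. For the compounds shown here, on the amide-type nitrogen, an isomeric change of the alkyl group alone gives an at least 140-fold higher number from compound 2 to compound 4 (2.15 log units; beyond the scatter), and the loss of one methyl from the chain gives an at least 100-fold higher number from compound 3 to compound 4 (2.00 log units; beyond the scatter), so this position separates alkyl groups that the earlier compounds did not distinguish. Replacing phenyl with propyl gives an at least 38-fold higher number from compound 1 to compound 4 (1.58 log units; beyond the scatter), the opposite direction to the isopropyl and isobutyl replacements, so an alkyl group in place of phenyl does not by itself lower the number.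

Whether the sharp rise belongs to unbranched chains generally stays open, since propyl is the only such group shown. An ethyl, a butyl or a cyclopropyl on the same nitrogen would show whether compound 4 is an isolated case.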